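The source may report more compounds than this note shows. Statements on the series, on what has been measured and on what is new or still open speak of the compounds shown alone.

Compound 1 `CCN(CC)CCCOc1cc2ncnc(Nc3nc4ccc(C(=O)Nc5c(C)cccc5C)cc4s3)c2cc1OC`, compound 2 `COc1cc2c(Nc3nc4ccc(C(=O)Nc5c(C)cccc5Cl)cc4s3)ncnc2cc1OCCCN1CCC(C)CC1`, compound 3 `COc1cc2c(Nc3nc4ccc(C(=O)Nc5c(C)cc(C)cc5C)cc4s3)ncnc2cc1OCCCN1CCCCC1` and the as yet unmeasured compound 4 `COc1cc2c(Nc3nc4ccc(C(=O)Nc5c(C)cccc5C)cc4s3)ncnc2cc1OCCCN1CCC(C)CC1` share one core and differ in the amine at the end of the side chain and in the substitution of the amide aryl group. In a functional assay on HCT-116 cells (Homo sapiens) for cytotoxicity, read by WST assay, with a stated time of 72 h (a lower number here means a stronger inhibitor, a higher number a weaker inhibitor), compound 1 gives only a limit, > 100000 nM. Compound 1 thus stands at the limit of > 100000 nM in this assay, at which 1 of the 3 values shown sits, so no number is known for it. Compound 2 gives 9100 nM in this assay, and compound 3 gives 16900 nM; these two values lie within the usual scatter of each other. The change from compound 1 to compound 4 is 4-methylpiperidin-1-yl in place of diethylamino on a saturated chain carbon, three bonds along the chain from an oxygen on an aromatic ring. Among the measured compounds shown here, no measured pair shows this step on its own, and compound 1 having only a limit leaves its true size open. A move toward a stronger inhibitor is nonetheless expected, with the step estimated as an at least 5.0-fold lower number from compound 1 to compound 4 (0.69 log units; beyond the scatter). That expectation rests on compound 2 at 9100 nM and on compound 3 at 16900 nM, both carrying a piperidine-type ring on the chain. Compound 4 is therefore expected to give about 20000 nM in this assay, with a likely range from 6000 nM to 70000 nM.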

Compound 4, half-maximal inhibitory concentration: > 100000 nM
Compound 4 gave a limit, no number; the forecaster's own chance of this, stated with the estimate: 25%; middle value at least 5.0-fold (0.69 log units) from the limit.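

In this assay, among the compounds shown here, methyl in place of chloro on an aromatic carbon of the amide aryl group gives an at least 10-fold higher number from compound 2 to compound 4 (1.04 log units; beyond the scatter), the first reading of a single change at this part of the molecule. With the 4-methylpiperidin-1-yl chain held fixed, this one substituent separates a measured value from a limit, so this amine on the chain does not by itself bring a number within reach of the assay. The step between compound 1 and compound 4 cannot be read, because both compounds sit at the limit: the limit of > 100000 nM in this assay, at which 2 of the 4 values shown sit.

As far as these compounds go, whether diethylamino and 4-methylpiperidin-1-yl would differ on a chloro-bearing amide aryl group remains open. So does how a bromo, methoxy or trifluoromethyl group on that aromatic carbon would read.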